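The compounds below may be only part of what the source reports. "The series", "measured", "known", "first", "only" and "open" are said of these compounds alone.

Measured compounds:
- compound 1, `COc1nc(N)nc2c1c(-c1cccs1)cn2[C@@H]1O[C@H](CO)[C@@H](O)[C@H]1O`: > 20000 nM
- compound 2, `COc1nc(N)nc2c1c(-c1ccoc1)cn2[C@@H]1O[C@H](CO)[C@@H](O)[C@H]1O`: > 20000 nM
- compound 3, `CSc1ncnc2c1c(-c1ccoc1)cn2[C@@H]1O[C@H](CO)[C@@H](O)[C@H]1O`: 3250 nM

The three measured compounds were tested in a functional assay on K562 cells (Homo sapiens), read by MTT assay, with a stated time of 72 h; a lower number here means a stronger inhibitor, a higher number a weaker inhibitor. Compound 1 gave only a limit of the assay, > 20000 nM. Compound 2 likewise gave only a limit, > 20000 nM. Among the compounds with values here, compound 3 is the one compound with a number, at 3250 nM in this assay.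

Compound 1 and compound 2 share a core and differ in one group: thiophen-2-yl in place of furan-3-yl on an aromatic carbon. The step that the two limits leave unreadable from compound 2 to compound 1 cannot be read, since both ends sit at the limit of > 20000 nM in this assay, at which 2 of the 3 values shown sit.

Compound 3 has a different core from compound 2; the difference between the two cores is not broken down here.

Compound 4, `CSc1ncnc2c1c(-c1cccs1)cn2[C@@H]1O[C@H](CO)[C@@H](O)[C@H]1O`, has not yet been measured. It differs from compound 3 by thiophen-2-yl in place of furan-3-yl on an aromatic carbon. The place of the change is described in the same words as for the change from compound 2 to compound 1, so this is the same change made on the core of compound 3.

Because the earlier step that the two limits leave unreadable from compound 2 to compound 1 gives no readable size, there is no measured guide to how thiophen-2-yl compares with furan-3-yl. The two groups are counted alike in ring size, hetero atom count, donors and acceptors, so the step of a 1.1-fold higher number from compound 3 to compound 4 (0.03 log units; within the scatter) is expected to be small. Compound 4 is therefore estimated at 3500 nM in this assay, with a likely range from 1200 nM to 12000 nM.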

Compound 4, half-maximal inhibitory concentration: > 20000 nM
Compound 4 gave a limit, no number (the forecaster's own chance of this, stated with the estimate: 20%); middle value at least 5.7-fold (0.75 log units) away from the limit.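

On the core of compound 3, putting thiophen-2-yl in place of furan-3-yl gives an at least 6.1-fold higher number from compound 3 to compound 4 (0.78 log units; beyond the scatter) in this assay, and this size is only a minimum: compound 4 gave a limit of the assay and not a number, so the true step could be larger. The same change on the core of compound 2, leading to compound 1, cannot be read, since both of those values are limits, so this series shows a clear loss on one core only and does not show that the change has the same size, or even the same direction, on the other. Any comparison of the two cores therefore has little to work with, and only compound 3 gives a number in this assay: the limit of > 20000 nM in this assay, at which 3 of the 4 values shown sit.

The compounds shown leave open whether the loss on the core of compound 3 comes from sulfur in place of oxygen or from the switch between a 3-yl and a 2-yl group, and furan-2-yl or thiophen-3-yl on that core would separate the two. As far as these compounds go, it also remains open how a plain phenyl ring or a pyridine ring in the same place would read in this assay.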